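Shortening the Chain on the Shared Core

This account rests on a few compounds, and the source may have more. Where it says the series, first, only, none or still open, it means among the compounds named here.

Among the measured compounds shown here, in a functional assay on MDA-MB-231 cells (Homo sapiens) for antiproliferative activity, read by MTT assay (on this read-out lower numbers stand for stronger inhibition and higher numbers for weaker inhibition), compound 2 `CCCCCCCCCCCC1(O)CC(=O)c2c(O)cc(O)cc2O1` gives 42800 nM, the highest of the two numbers measured so far, while compound 1 `CCCCC/C=C\C/C=C\CCCCCCCC1(O)CC(=O)c2c(O)cc(O)cc2O1` gives 6790 nM. Compound 3 `CCCCC1(O)CC(=O)c2c(O)cc(O)cc2O1` differs from compound 2 by hydrogen in place of heptyl on a saturated chain carbon, four bonds along the chain from a saturated ring carbon. For the measured compounds named here, the one measured step that bears on this, a 6.3-fold higher number from compound 1 to compound 2 (0.80 log units; beyond the scatter), also shortened the chain and moved the number upward; cutting the chain further is therefore expected to raise it again, by a 3.5-fold higher number from compound 2 to compound 3 (0.54 log units; beyond the scatter). Compound 3 is estimated at 150000 nM in this assay, with a range from 40000 nM to 500000 nM.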

Compound 3, half-maximal inhibitory concentration: > 87000 nM
Compound 3: only a limit was reported; the forecaster's own chance of this, stated with the estimate: 40%; the middle value does not contradict the limit.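

In this assay, going by these compounds, hydrogen in place of heptyl gives an at least 2.0-fold higher number from compound 2 to compound 3 (0.30 log units; that floor lies within the scatter), so this change has only a floor and its true size remains unknown. Compound 3 has a limit, not a number: the limit of > 87000 nM in this assay, at which 1 of the 3 values shown sits.

The earlier compounds shown here gave a measured step, whereas here the direction matches that step but the floor does not establish a change beyond the scatter. On these data alone, whether an amine or a carboxylic acid in place of the heptyl would lower the number remains open. So does whether a longer saturated chain would match compound 1.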